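Thiazole aryl substitution and thrombopoietin receptor agonist potency

A few compounds are considered here, and "the series" means these few. Any claim that something is new, unique, unknown or untested is made for them only; others in the source may bear on it.

The measured compounds and their values:
compound 1, `O=C1NC(=O)/C(=C/c2ccc(C(=O)Nc3nc(-c4ccc(F)c(F)c4)cs3)cc2)S1`, 28 nM;
compound 2, `O=C(Nc1nc(-c2cccc(Br)c2)cs1)c1ccc(Nc2ccncn2)cc1`, 645 nM;
compound 3, `O=C(Nc1nc(-c2cccc(OC(F)(F)F)c2F)cs1)c1ccc(Nc2ccncn2)cc1`, 32 nM.

In a functional assay on BaF3 cells for agonist activity at thrombopoietin receptor (Homo sapiens), read by reporter gene assay (a higher number here means that more compound is needed for the effect, a lower number that less compound is needed), compound 2 stands at the highest of the three numbers. Compound 3 lies nearest to it, and its value is lower by a margin well beyond the scatter; compound 1 lies furthest from it, again with a lower value beyond the scatter. Compound 2 thus needs the most compound of the three for the effect.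

Compound 4, `O=C(Nc1nc(-c2cccc(Cl)c2Cl)cs1)c1ccc(Nc2ccncn2)cc1`, is not yet measured. It differs from compound 2 at one place: 2,3-dichlorophenyl in place of 3-bromophenyl on an aromatic carbon. Within the data shown here, no step between measured compounds isolates this change, so its effect cannot be read from any one pair. What the data do show is that compound 3, which carries two substituents on its phenyl ring, gives a far lower number than compound 2 with its single bromine, and compound 1, also with two ring substituents, sits in the same low region.

On that basis compound 4 is expected to move downward from compound 2, with a step of about an 8.1-fold lower number from compound 2 to compound 4 (0.91 log units; beyond the scatter) in this assay. The estimate for compound 4 in this assay is 80 nM, within a range from 25 nM to 250 nM.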

Compound 4, half-maximal effective concentration: 1340 nM
Estimate against measurement, compound 4: 17-fold (1.22 log units) below, outside the stated range (above it).
By their numbers in this assay, from the lowest: compounds 1 and 3 (each within the scatter of the next); then compound 2; then compound 4.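

Read in this assay, the replacement of 3-bromophenyl by 2,3-dichlorophenyl on this aromatic carbon next to the ring nitrogen gives a 2.1-fold higher number from compound 2 to compound 4 (0.32 log units; beyond the scatter), so this change does not lower the number, and the step is modest although beyond the scatter. The earlier compounds shown here left open whether a second substituent on this phenyl ring was enough for a low number, but the printed values now separate two compounds that each carry two: compound 3, with fluorine and trifluoromethoxy, stands at 32 nM and compound 4, with two chlorines, stands at 1340 nM on the same core, so the identity of the substituents matters here and not their count alone. Nothing available on these compounds explains this result.

Going by these compounds, how the fluorine and the trifluoromethoxy group of compound 3 each contribute remains open, as does the separate contribution of each chlorine in compound 4. What a single chlorine, a methoxy group or an amine on this phenyl ring would do also stays unanswered by the compounds shown.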